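The source may hold more compounds than are shown below. What is called first, only, known or untested is meant among the compounds shown, and "the series" means these compounds.

Measured so far in a functional assay on P388 cells (Mus musculus) for inhibition, read by MTT assay, with a stated time of 72 h; a higher number here means a weaker inhibitor, a lower number a stronger inhibitor:
- compound 1 `Cc1cccc(NC(=O)c2ccc(/N=N\c3c[nH]c4ccccc34)cc2)c1C`: 51600 nM
- compound 2 `O=C(Nc1ccc([N+](=O)[O-])cc1)c1ccc(/N=N\c2c[nH]c3ccccc23)cc1`: 11200 nM

Compound 2 stands with the lowest number of the two; its nearest neighbour is compound 1, which gives a higher number, the step being a 4.6-fold lower number from compound 1 to compound 2 (0.66 log units; beyond the scatter). Among the compounds with values here, the only change in that step was 4-nitrophenyl in place of 2,3-dimethylphenyl on the amide-type nitrogen.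

Compound 3 `Cc1cccc(NC(=O)c2ccc(/N=N\c3c[nH]c4ccccc34)cc2)c1` has not been measured. It differs from compound 2 by 3-methylphenyl in place of 4-nitrophenyl on an amide-type nitrogen. Within the data shown here, this change bears directly on the one measured step: it removes the 4-nitrophenyl that the step from compound 1 to compound 2 brought in and replaces it with a methyl-substituted phenyl, though not the same group as the 2,3-dimethylphenyl of compound 1. Among the measured compounds shown here, that measured step, a 4.6-fold lower number from compound 1 to compound 2 (0.66 log units; beyond the scatter), is the only guide, and it points to a move back towards the number of compound 1. For the measured compounds named here, compound 3 is therefore expected to show a higher number than compound 2, by about a 3.1-fold higher number from compound 2 to compound 3 (0.49 log units; beyond the scatter), with wide uncertainty since 3-methylphenyl has no measured counterpart. The estimate for compound 3 in this assay is 35000 nM, with a range of 12000 nM to 100000 nM.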

Compound 3, half-maximal inhibitory concentration: 300 nM
Estimate against measurement, compound 3: 120-fold (2.07 log units) above; measured number outside the range, below it.
By their numbers in this assay, from the lowest: compound 3; then compound 2; then compound 1.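

In this assay, within the data shown here, the group on the amide-type nitrogen sets the number to a far greater extent than the first pair of compounds showed: 3-methylphenyl in place of 4-nitrophenyl gives a 37-fold lower number from compound 2 to compound 3 (1.57 log units; beyond the scatter), so a methyl-bearing phenyl does not in itself go with a weak inhibitor. The sharpest contrast lies within the methyl-bearing phenyl groups, where hydrogen in place of methyl on an aromatic carbon gives a 170-fold lower number from compound 1 to compound 3 (2.24 log units; beyond the scatter), placing 3-methylphenyl and 2,3-dimethylphenyl at opposite ends of the three compounds despite a difference of one methyl. Nothing available explains why this single methyl matters so much.

As far as these compounds go, it remains open whether the methyl that stays in compound 3 contributes at all, a question that an unsubstituted phenyl on the same nitrogen would address, and whether an ethyl, methoxy or chlorine in place of that methyl would hold the number. Among these compounds, with only three compounds on one core in one cell assay, it is also open whether the large effect of the removed methyl would carry over to other groups on this nitrogen.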